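Solubility on Adding an Isopropylcarbamoyl Group

The compounds below may be only part of what the source reports. "The series", "measured", "known", "first", "only" and "open" are said of these compounds alone.

Compound 1, `CNC(=O)c1cc(C(=O)NCCCC2CNCCO2)cn(Cc2ccccc2)c1=O`, is reported in a physicochemical assay for solubility (on this read-out lower numbers stand for lower solubility and higher numbers for higher solubility), only as a limit, >= 194 ug/mL.
Compound 2, `CCNC(=O)c1cc(C(=O)NC)c(=O)n(Cc2ccccc2)c1`, is likewise reported in this assay only as a limit, >= 144 ug/mL.
Compound 3, `CNC(=O)c1cccn(Cc2ccccc2)c1=O`, gives in this assay a number, 78 ug/mL.

Within the data shown here, compound 3 thus stands as the one compound with an actual number; the two other values are limits and not numbers. Among the measured compounds shown here, of the measured steps, the one from compound 2 to compound 3 bears directly on the change at hand: an at least 1.8-fold lower number from compound 2 to compound 3 (0.26 log units; that floor lies within the scatter). The step from compound 1 to compound 2 is a step that the two limits leave unreadable from compound 1 to compound 2 and offers no usable size. Compound 4, `CNC(=O)c1cc(C(=O)NC(C)C)cn(Cc2ccccc2)c1=O`, is the compound not yet measured; its change from compound 3 is isopropylcarbamoyl in place of hydrogen on an aromatic carbon. This runs the same kind of step as that from compound 2 to compound 3 in the opposite direction, with an isopropylcarbamoyl entering where an ethylcarbamoyl had left. The number for compound 4 in this assay is accordingly expected to rise, by an estimated 1.9-fold higher number from compound 3 to compound 4 (0.28 log units; within the scatter). Compound 4 is estimated at 150 ug/mL, expected to fall between 70 ug/mL and 320 ug/mL.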

Compound 4, solubility: >= 136 ug/mL
Compound 4: only a limit was reported (the forecaster's own chance of this, stated with the estimate: 40%); the middle value does not contradict the limit.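

The isopropylcarbamoyl group on the aromatic carbon two atoms from the ring nitrogen gives, in this assay, an at least 1.7-fold higher number from compound 3 to compound 4 (0.24 log units; that floor lies within the scatter). Before this, the only readable step at this position was the one involving the ethylcarbamoyl group of compound 2, so compound 4 adds a second carbamoyl group with the same direction of step, although only the floor of its size can be read. Compound 4 itself is held only by a limit: the limit of >= 136 ug/mL in this assay, at which 1 of the 4 values shown sits.

The steps joining compound 4 to compound 1 and to compound 2 cannot be read, all three values being limits, so the isopropylcarbamoyl, ethylcarbamoyl and 3-(morpholin-2-yl)propyl-bearing amides cannot be placed in any order. On these data alone, how a carboxylic acid or a simple primary amide at this position would compare remains open.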